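A few compounds are considered here, and "the series" means these few. Any claim that something is new, unique, unknown or untested is made for them only; others in the source may bear on it.

Compound 1 `Cc1ccccc1N1CCC(C(=O)Nc2ccc3c(c2)NC(=O)CO3)CC1` and compound 2 `CC(=O)N1CCc2ccc(NC(=O)C3CCN(c4cccc(C(F)(F)F)c4)CC3)cc21` are the two compounds for which a number has been obtained. In a functional assay for antagonist activity at transient receptor potential cation channel subfamily V member 1 (Homo sapiens), read by FLIPR and calcium flux (on this read-out higher numbers stand for weaker inhibition and lower numbers for stronger inhibition), compound 1 gives 150 nM, and compound 2 gives 800 nM. Compound 1 therefore stands at the lowest of the two numbers, and the gap to compound 2 lies beyond the scatter; since the two compounds differ in more than one place, nothing beyond what those two values show can be taken from the pair.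

Compound 3 `Cc1cccc(N2CCC(C(=O)Nc3ccc4c(c3)NC(=O)CO4)CC2)c1C` has not yet been measured. It differs from compound 1 by methyl in place of hydrogen on an aromatic carbon. Among the compounds with values here, no measured pair in this set shows a change of this kind, so there is no measured guide to the size of the step. The step of a 1.3-fold lower number from compound 1 to compound 3 (0.10 log units; within the scatter) is expected to stay within the scatter, leaning if anything toward stronger inhibition. Compound 3 is accordingly estimated at 120 nM in this assay, with a range from 40 nM to 400 nM, and the measurement will tell whether that holds.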

Compound 3, half-maximal inhibitory concentration: 60 nM
Estimate against measurement, compound 3: 2.0-fold (0.30 log units) above; measured number inside the range.
By their numbers in this assay, from the lowest: compound 3; then compound 1; then compound 2.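

In this assay, the change from 2-methylphenyl to 2,3-dimethylphenyl gives a 2.5-fold lower number from compound 1 to compound 3 (0.40 log units; beyond the scatter), so a methyl group on this aromatic carbon, ortho to a methyl group and meta to a large group, goes with stronger inhibition. Within the data shown here, this is the first pair in the set that differs in only one place, and it gives a first measured size for this kind of change: the entering group adds 1 heavy atom, with no ring, 0 hydrogen-bond donors, 0 hydrogen-bond acceptors and no net charge. The data at hand offer no independent measurement that accounts for the link between the added methyl and the stronger inhibition.

The compounds shown hold no other group at this place, so it remains open whether an ethyl group, a methoxy group, a chlorine atom or an amine would give a similar step. As far as these compounds go, it also remains open whether the same methyl would give a step of this size on the core of compound 2, or on any aromatic ring carrying a different neighbouring group.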